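Adding a third fluoro: from compound 2 toward compound 3

A few compounds are considered here, and "the series" means these few. Any claim that something is new, unique, unknown or untested is made for them only; others in the source may bear on it.

Measured so far, in an assay on V79 cells for inhibition of cytochrome P450 11B2, mitochondrial (Homo sapiens), tested at 500 nM; a lower number here means less inhibition, a higher number more inhibition at the concentration tested (going by the name of the read-out):
- compound 1 `O=C(Nc1cccnc1)c1ccc(OC(F)(F)F)cc1` gives 3%
- compound 2 `O=C(Nc1cccnc1)c1ccc(F)c(F)c1` gives 83%

Compound 2 stands highest of the two numbers measured. Its nearest neighbour, compound 1, lies far below it, and that gap is beyond the usual scatter of repeated measurements. Among the measured compounds shown here, no pair of measured compounds differs in just one place, so no single-change step is available as a guide.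

Compound 3 `O=C(Nc1cccnc1)c1cc(F)c(F)cc1F` has not yet been measured. It differs from compound 2 in one place: fluoro in place of hydrogen on an aromatic carbon. For the measured compounds named here, nothing among the measured compounds shows what this kind of change does here. Because compound 2 already gives 83%, the room for a further rise is limited. The expected step is small, downward if anything, and within the scatter: a number 8 percentage points lower from compound 2 to compound 3 (within the scatter). Compound 3 is therefore estimated at 75%, with a range from 45% to 92%.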

Compound 3, a percentage reported as inhibition, at one concentration (the size of the read-out at that concentration, not a potency): 70%
The estimate for compound 3 lay 5 percentage points above the measured number, and the stated range covers the measured number.
By their numbers in this assay, from the lowest: compound 1; then compound 3; then compound 2.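

In this assay, among the compounds shown here, fluoro in place of hydrogen on an aromatic carbon, ortho to a group of 9 heavy atoms, gives the first single-change step: a number 13 percentage points lower from compound 2 to compound 3 (beyond the scatter). The position therefore responds to this small change, and a third fluoro here costs a modest part of the inhibition without abolishing it, a reading that rests on this one pair. Nothing measured bears on the reason for the step.

The compounds shown leave open whether the step belongs to fluoro itself or to any replacement of hydrogen at this position, as a chloro, a methoxy or an amine there would show. They also leave open how much the step depends on the fluoro groups meta and para to this carbon.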